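The compounds below may be only part of what the source reports. "The series", "measured", "known", "first", "only" and "open" are said of these compounds alone.

Working notes on the series. In a functional assay on MKN-74 cells (Homo sapiens) for antiproliferative activity, with a stated time of 24 h (a higher number here means a weaker inhibitor, a lower number a stronger inhibitor), compound 1 `Cc1ccc(C(=O)Nc2sc3c(c2C(N)=O)CCN(C(=O)Nc2ccccc2Cl)C3)cc1` gives 27600 nM. Compound 2 `NC(=O)c1c(NC(=O)c2cccc([N+](=O)[O-])c2)sc2c1CCN(C(=O)Nc1ccccc1Cl)C2` carries one change relative to compound 1 3-nitrophenyl in place of 4-methylphenyl on a carbonyl carbon and in this assay compound 2 gives 22700 nM, a step of a 1.2-fold lower number from compound 1 to compound 2 (0.08 log units; within the scatter). Compound 3 `Cc1ccc(C(=O)Nc2sc3c(c2C(N)=O)CCN(C(=S)Nc2cc(C(F)(F)F)cc(C(F)(F)F)c2)C3)cc1` rests on a different core; how its core differs from that of compound 1 is not broken down here. In this assay compound 3 gives 14900 nM; its gaps to compound 1 and to compound 2 are both within the scatter, so no order among the three can be read from these numbers.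

Compound 4 `NC(=O)c1c(NC(=O)c2cccc([N+](=O)[O-])c2)sc2c1CCN(C(=S)Nc1cc(C(F)(F)F)cc(C(F)(F)F)c1)C2` is not yet measured. It stands to compound 3 as compound 2 stands to compound 1 (3-nitrophenyl in place of 4-methylphenyl on a carbonyl carbon), and the surroundings of the place are the same in both pairs, so this is the same change made on the other core. The expected step in this assay is a 1.2-fold lower number from compound 3 to compound 4 (0.08 log units; within the scatter), set beside the measured one of a 1.2-fold lower number from compound 1 to compound 2 (0.08 log units; within the scatter), and it rests on compound 3 at 14900 nM as the starting point. The estimate for compound 4 is 12500 nM, expected to fall between 5000 nM and 32000 nM.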

Compound 4, half-maximal inhibitory concentration: 25800 nM
Beside the measured number, compound 4's estimate is 2.1-fold (0.31 log units) below it; the range from low to high includes it.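

In this assay, 3-nitrophenyl in place of 4-methylphenyl on a carbonyl carbon gives a 1.7-fold higher number from compound 3 to compound 4 (0.24 log units; within the scatter), so the change stays inside the scatter on the core of compound 3, as it did on the core of compound 1. Set together, the two steps cannot be told apart: the same change on two cores in this assay, a 1.2-fold lower number (0.08 log units; within the scatter) from compound 1 to compound 2 and a 1.7-fold higher number (0.24 log units; within the scatter) from compound 3 to compound 4, 2.1-fold (0.32 log units) apart, within the scatter of two such steps. This shows that the change can be carried between these two cores without a readable difference in the step, but it does not show that the change is without effect, nor that the steps match in size, and two cores say nothing about others in the series.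

Still open, on these data alone, is whether any group at this place moves the number beyond the scatter, for example an aliphatic amine or a carboxylic acid in place of the 4-methylphenyl. Also open, as far as these compounds go, is whether a step of readable size would carry from one core to the other.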